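The compounds below may be only part of what the source reports. "The series", "measured", "known", "first", "only" and "open" are said of these compounds alone.

Measured in a functional assay on MCF7 cells (Homo sapiens) for antiproliferative activity, read by sulforhodamine B assay, with a stated time of 48 h; a lower number here means a stronger inhibitor, a higher number a weaker inhibitor:
- Compound 1 `COc1ccc(C(=O)/C=C/c2ccccc2-c2ccc(F)nc2)cc1`: 13000 nM
- Compound 2 `O=C(/C=C/c1ccccc1-c1ccc(F)nc1)c1cccc(O)c1`: 12000 nM
- Compound 3 `COc1ccc(C(=O)/C=C/c2ccccc2-c2ccc(F)cc2)cc1O`: 560 nM

Compound 3, at 560 nM, has the lowest number of the three in this assay. Compound 4 `COc1ccc(C(=O)/C=C/c2ccccc2-c2ccc(F)nc2)cc1O` has 6-fluoropyridin-3-yl in place of 4-fluorophenyl on an aromatic carbon, and the rest of compound 3 is unchanged.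

Among the measured compounds shown here, no measured step isolates this exchange. The only one, a 1.1-fold lower number from compound 1 to compound 2 (0.03 log units; within the scatter), lies within the scatter and concerns the group on the carbonyl instead. Compound 1 at 13000 nM and compound 2 at 12000 nM do carry 6-fluoropyridin-3-yl, but they also differ from compound 3 on the carbonyl side, so their higher numbers cannot be assigned to either place alone. Compound 4 keeps the carbonyl side of compound 3, so it is expected to stay much closer to compound 3 than to those two. A modest rise in the number is expected, estimated as a 1.8-fold higher number from compound 3 to compound 4 (0.25 log units; within the scatter). Compound 4 is estimated at 1000 nM, with an expected range of 300 nM to 5000 nM.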

Compound 4, half-maximal inhibitory concentration: 2000 nM
The estimate for compound 4 lay 2.0-fold (0.30 log units) below the measured number; the measured number falls inside the stated range.
By their numbers in this assay, from the lowest: compound 3; then compound 4; then compounds 2 and 1 (each within the scatter of the next).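

In this assay, the exchange of 4-fluorophenyl for 6-fluoropyridin-3-yl, on an aromatic carbon ortho to a large group, now has a step of its own, a 3.6-fold higher number from compound 3 to compound 4 (0.55 log units; beyond the scatter) in this place, so the position is not indifferent to this change. With 6-fluoropyridin-3-yl held fixed, the carbonyl side also matters, giving a 6.0-fold lower number from compound 2 to compound 4 (0.78 log units; beyond the scatter) for methoxy in place of hydrogen on an aromatic carbon and a 6.5-fold lower number from compound 1 to compound 4 (0.81 log units; beyond the scatter) for hydroxy in place of hydrogen on an aromatic carbon. The higher numbers of compound 1 and compound 2 therefore cannot rest on 6-fluoropyridin-3-yl alone.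

The compounds shown leave open how an amine or a carboxylic acid in place of the fluorine would fare at this position. Nothing available explains why the exchange raises the number.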